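Nitro for Fluoro on the Phenoxy Ring

The source may report more compounds than this note shows. Statements on the series, on what has been measured and on what is new or still open speak of the compounds shown alone.

Measured so far:
compound 1, `O=C(CSc1nc2ccccc2s1)N/N=C/c1ccc(Oc2ccccc2)cc1`, 5.6
compound 2, `O=C(CSc1nc2ccccc2s1)N/N=C/c1ccc(Oc2ccc(F)cc2)cc1`, 5.5

In a physicochemical assay for lipophilicity, in phosphate buffer, measured as octanol-water partition, with a stated time of 24 h (a lower number here means a more polar compound, a higher number a more lipophilic compound), compound 2 gives 5.5, the lower of the two numbers, with compound 1 nearest at 5.6, the two lying within the scatter of each other. Among the compounds with values here, the only measured step, a number 0.10 log units lower from compound 1 to compound 2 (within the scatter), concerns the replacement of hydrogen by fluoro and was within the scatter.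

Compound 3, `O=C(CSc1nc2ccccc2s1)N/N=C/c1ccc(Oc2ccc([N+](=O)[O-])cc2)cc1`, has not been measured in this assay. It differs from compound 2 in one place: nitro in place of fluoro on an aromatic carbon. No measured step concerns a nitro group, so the expectation rests on what this counted difference shows rather than on a shown step. On that basis compound 3 is expected to come out somewhat lower than compound 2, the step of a number 0.40 log units lower from compound 2 to compound 3 (beyond the scatter) being the estimated size. Compound 3 is therefore estimated at 5.1, with a range from 4.6 to 5.6.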

Compound 3, partition coefficient: 5.3
Estimate against measurement, compound 3: 0.20 log units below, within the range that was stated.
By their numbers in this assay, from the lowest: compounds 3, 2 and 1 (each within the scatter of the next).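

In this assay, nitro in place of fluoro (a number 0.20 log units lower from compound 2 to compound 3 (within the scatter)) and nitro in place of hydrogen (a number 0.30 log units lower from compound 1 to compound 3 (within the scatter)) both leave the number within the scatter. The earlier pair had shown this only for fluoro, a single heavy atom with no hydrogen-bond acceptors. On this aromatic carbon, para to a large group, the same now holds for nitro, which brings more heavy atoms and adds hydrogen-bond acceptors, so hydrogen, fluoro and nitro are not told apart here, and nothing available offers an explanation for this.

From the compounds shown here alone, whether an amine or a carboxylic acid on this same carbon would also stay within the scatter remains open. So does whether nitro in place of fluoro would read the same way elsewhere on the core of compound 1.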